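The source may hold more compounds than are shown below. What is called first, only, known or untested is meant among the compounds shown, and "the series" means these compounds.

Compound 1 `CCn1c(C)c(C(=O)O)c(-c2cccc(N3CCN(c4ccc(NS(=O)(=O)c5ccc(N[C@H](CCN6CCC(O)CC6)CSc6ccccc6)c(S(=O)(=O)C(F)(F)F)c5)cc4)CC3)c2)c1-c1ccc(Cl)cc1` gives 1.2 nM in an assay for binding affinity to Apoptosis regulator Bcl-2 (Homo sapiens), read by fluorescence polarization, with a stated time of 2 h; a lower number here means a stronger inhibitor, a higher number a weaker inhibitor. Compound 2 `CCOc1cccc(S(=O)(=O)Nc2ccc(N3CCN(c4cccc(-c5c(C(=O)NCCCN6CCN(C)CC6)c(C)n(C)c5-c5ccc(Cl)cc5)c4)CC3)cc2)c1` gives 420 nM in this assay, the higher of the two numbers, and the gap to compound 1 lies well beyond the scatter. Compound 3 `COc1cccc(S(=O)(=O)Nc2ccc(N3CCN(c4cccc(-c5c(C(=O)NCCCN6CCN(C)CC6)c(C)n(C)c5-c5ccc(Cl)cc5)c4)CC3)cc2)c1` differs from compound 2 by a single change: hydrogen in place of methyl on a saturated chain carbon bound to an oxygen on an aromatic ring. Among the compounds with values here, no measured pair shows this change, so its size is unknown. Trimming ethoxy to methoxy is expected to move this assay little, and the expected step is a 1.1-fold higher number from compound 2 to compound 3 (0.03 log units; within the scatter), within the scatter. Compound 3 is therefore estimated at 450 nM, in the range 200 nM to 1000 nM.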

Compound 3, inhibition constant: 207 nM
The estimate for compound 3 lay 2.2-fold (0.34 log units) above the measured number, and the stated range covers the measured number.
By their numbers in this assay, from the lowest: compound 1; then compound 3; then compound 2.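

Trimming ethoxy to methoxy is the first change at this position with a measured size: this assay shows a 2.0-fold lower number from compound 2 to compound 3 (0.31 log units; beyond the scatter). Removing this single methyl from the 3-ethoxyphenyl group therefore shifts the reading modestly rather than leaving it unchanged, contrary to what a change this small might suggest. Nothing measured on either group bears on this step.

Going by these compounds, whether a hydroxy group, an amine or a longer propoxy chain in place of ethoxy would continue in this direction remains open. One step cannot establish a trend.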